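Imidazolyl for Pyrrolidinyl on Two Carbamate Chains

A few compounds are considered here, and "the series" means these few. Any claim that something is new, unique, unknown or untested is made for them only; others in the source may bear on it.

Measured so far:
compound 1 `COC(=O)N(C)CC#CCN1CCCC1` — > 10 mg/kg
compound 2 `COC(=O)N(C)CC#CCn1ccnc1` — > 100 mg/kg
compound 3 `CCOC(=O)N(C)C(C)C#CCN1CCCC1` — > 100 mg/kg

In a functional assay on the whole organism for antagonist activity, with Mus musculus as the target (on this read-out lower numbers stand for an effect already at smaller amounts and higher numbers for an effect only at larger amounts of compound), the value of compound 1 is a limit of the assay, not a number. The value of compound 2 in this assay is also a limit. The value of compound 3 in this assay is a limit as well. The change 1H-imidazol-1-yl in place of pyrrolidin-1-yl on a saturated chain carbon bound to a triple-bonded carbon therefore yields a step that the two limits leave unreadable from compound 1 to compound 2. Compound 4 `CCOC(=O)N(C)C(C)C#CCn1ccnc1` carries the same change relative to compound 3, (1H-imidazol-1-yl in place of pyrrolidin-1-yl on a saturated chain carbon bound to a triple-bonded carbon). How the core of compound 3 differs from the core of compound 1 is not broken down here. Because compound 3 sits at the limit of > 100 mg/kg in this assay, at which 2 of the 3 values shown sit, the expected step is a step that the limit leaves unreadable from compound 3 to compound 4, which is no more than a guess from limits. Compound 4 is accordingly estimated at 300 mg/kg, most likely again only a limit.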

Compound 4, dose for half-maximal effect: 66 mg/kg
Beside the measured number, compound 4's estimate is 4.5-fold (0.66 log units) above it; measured number below the stated range.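

In this assay, 1H-imidazol-1-yl in place of pyrrolidin-1-yl gives an at least 1.5-fold lower number from compound 3 to compound 4 (0.18 log units; that floor lies within the scatter). The same change on the core of compound 1 leaves a step from compound 1 to compound 2 that cannot be read, so no measured step on a second core stands beside this one, and carrying the change from one core to another is not shown. The value of compound 3 is a limit of the assay, not a number, so the true size of the step also stays open: the limit of > 100 mg/kg in this assay, at which 2 of the 4 values shown sit.

On these data alone, it remains open how another group on a saturated chain carbon bound to a triple-bonded carbon, such as piperidin-1-yl or dimethylamino, would read on either core. As far as these compounds go, it is equally open whether any such group on the core of compound 1 would give a number rather than a limit.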